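The compounds below may be only part of what the source reports. "The series", "measured", "known", "first", "only" and "open" are said of these compounds alone.

Measured compounds in an ADME assay on BaF3 cells (Mus musculus) for cytotoxicity, read by CellTiter-Glo and CCK-8 assay, with a stated time of 72 h; a higher number here means a weaker inhibitor of growth, a lower number a stronger inhibitor of growth:
- compound 1, `CCC(=O)NCc1ccc(C(=O)Nc2ccc(C)c(Nc3nccc(-c4cccnc4)n3)c2)cc1`: > 10000 nM
- compound 2, `C=CC(=O)Nc1cccc(C(=O)Nc2ccc(C)c(Nc3nccc(-c4cccnc4)n3)c2)c1`: 2480 nM
- compound 3, `C=CC(=O)Nc1cc(C(=O)Nc2ccc(C)c(Nc3nccc(-c4cccnc4)n3)c2)cc(C(F)(F)F)c1`: 5460 nM

Compound 1 gives only a limit in this assay, the value > 10000 nM being the assay limit and not a number; the limit of > 10000 nM in this assay, at which 1 of the 3 values shown sits, marks where it sits. Within the data shown here, compounds 2 and 3, which share the core with compound 1, both give measurable numbers, and the one step between them, a 2.2-fold higher number from compound 2 to compound 3 (0.34 log units; beyond the scatter), is the only measured step in the set. Among the measured compounds shown here, no measured step covers the change from compound 1 to compound 4.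

Compound 4, `C=CC(=O)N(CCN(CC)CC)Cc1ccc(C(=O)Nc2ccc(C)c(Nc3nccc(-c4cccnc4)n3)c2)cc1`, differs from compound 1 by (2-(diethylamino)ethyl)(vinylcarbonyl)amino in place of propanoylamino on a saturated chain carbon bound to an aromatic carbon. The entering group carries the vinylcarbonyl unit, and the two compounds in the set that give numbers rather than a limit are the ones whose structures hold such a unit on the amide side chain; compound 1, without it, stands at the limit. For the measured compounds named here, on that ground alone, and with no direct step to size it, a move from the limit down into the measurable range is expected for compound 4, with the step of an at least 2.8-fold lower number from compound 1 to compound 4 (0.45 log units; beyond the scatter) as the estimate. Compound 4 is therefore expected to give about 3500 nM in this assay, within a range of 800 nM to 12000 nM, with a real chance that only a limit is again reported.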

Compound 4, concentration for 50% growth inhibition: 5450 nM
Beside the measured number, compound 4's estimate is 1.6-fold (0.19 log units) below it, within the range that was stated.
By their numbers in this assay, from the lowest: compound 2; then compounds 4 and 3 (each within the scatter of the next). At a limit, above all of these: compound 1.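

In this assay, compound 1 gives > 10000 nM, which is a limit of the assay and not a number: the limit of > 10000 nM in this assay, at which 1 of the 4 values shown sits. Among these compounds, on the saturated chain carbon bound to an aromatic carbon, (2-(diethylamino)ethyl)(vinylcarbonyl)amino in place of propanoylamino gives the first measured number for a group at this place, with compound 4 at 5450 nM. The step is an at least 1.8-fold lower number from compound 1 to compound 4 (0.26 log units; that floor lies within the scatter), so a number is reached but its floor does not establish a change beyond the scatter.

The vinylcarbonyl and 2-(diethylamino)ethyl parts enter together, so the result cannot be assigned to either one. Open, from the compounds shown here alone, is how the number would respond to a methyl on that amide nitrogen, or to a morpholine in place of the diethylamino end of the chain.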